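Swapping the ester's cyclohexyl for allyl in a thiophene amide series

This account rests on a few compounds, and the source may have more. Where it says the series, first, only, none or still open, it means among the compounds named here.

Of the compounds shown here, three sharing one core have been tested in a toxicity assay on HUVEC cells (Homo sapiens) for inhibition; a higher number here means a weaker inhibitor of growth, a lower number a stronger inhibitor of growth. Compound 1 `COC(=O)c1ccsc1NC(=O)[C@@H]1CCCN1` stays at the limit of the assay, giving > 250 ug/mL. Compound 2 `O=C(OCc1ccccc1)c1ccsc1NC(=O)[C@@H]1CCCN1` also reaches only the limit, giving > 250 ug/mL. For the measured compounds named here, compound 3 `O=C(OC1CCCCC1)c1ccsc1NC(=O)[C@@H]1CCCN1` is the one member with a number, giving 137 ug/mL in this assay, so it is the sole anchor for any comparison. The steps leading to it read an at least 1.8-fold lower number from compound 1 to compound 3 (0.26 log units; that floor lies within the scatter) and an at least 1.8-fold lower number from compound 2 to compound 3 (0.26 log units; that floor lies within the scatter), while a step that the two limits leave unreadable from compound 1 to compound 2 cannot be read because of the limit of > 250 ug/mL in this assay, at which 2 of the 3 values shown sit.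

Compound 4 `C=CCOC(=O)c1ccsc1NC(=O)[C@@H]1CCCN1` differs from compound 3 by allyl in place of cyclohexyl on an oxygen next to a carbonyl group. Both steps that bear on this change point the same way: the smaller methyl and the benzyl both gave a weaker inhibitor than the cyclohexyl, so the return to a three-carbon chain is expected to move the number back up. The step from compound 3 to compound 4 is therefore estimated as a 1.8-fold higher number from compound 3 to compound 4 (0.24 log units; within the scatter), a rise that could carry compound 4 back to the limit. Compound 4 is expected to give about 240 ug/mL in this assay, with a likely range of 120 ug/mL to 450 ug/mL.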

Compound 4, concentration for 50% growth inhibition: 149 ug/mL
The estimate for compound 4 lay 1.6-fold (0.21 log units) above the measured number; the range from low to high includes it.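

Until now only one ester in this set had a real number in this assay; a second one now gives a fully readable step, a 1.1-fold higher number from compound 3 to compound 4 (0.04 log units; within the scatter), so at this position on an oxygen next to a carbonyl group, cyclohexyl and allyl cannot be told apart, even though allyl has no ring and fewer heavy atoms. Against the other two esters the new compound gives only floors, an at least 1.6-fold lower number from compound 1 to compound 4 (0.22 log units; that floor lies within the scatter) and an at least 1.6-fold lower number from compound 2 to compound 4 (0.22 log units; that floor lies within the scatter), and neither floor clears the scatter. Those two steps stay open-ended because compound 1 and compound 2 each sit at a limit and not at a number: the limit of > 250 ug/mL in this assay, at which 2 of the 4 values shown sit.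

On these data alone, how far compound 1 and compound 2 truly lie from compound 4 stays open. So does whether a longer chain, an amine or a carboxylic acid on this oxygen's group would move the number beyond the scatter.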